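The source may report more compounds than this note shows. Statements on the series, on what has been measured and on what is new or still open speak of the compounds shown alone.

Of the compounds shown here, two of one shared core have been measured in a functional assay (muscle tissue) with Cavia porcellus as the target; on this read-out higher numbers stand for an effect only at larger amounts of compound and lower numbers for an effect already at smaller amounts. Compound 1, `COC(=O)C1=C(C)N=C(C)/C(=C(\O)OC)C1c1c(F)c(F)c(F)c(F)c1F`, gives 4.37 nM in this assay. Compound 2, `COC(=O)C1=C(C)N=C(C)/C(=C(\O)OC)C1c1ccc(F)cc1`, gives 129 nM and so has the higher of the two numbers, lying a long way from compound 1, well beyond the usual scatter. The account now turns to compound 3, `COC(=O)C1=C(C)N=C(C)/C(=C(\O)OC)C1c1ccc(C#N)cc1`, which has not yet been measured. Its structure differs from compound 2 in one place: cyano in place of fluoro on an aromatic carbon. Among the compounds with values here, no pair of measured compounds shows this exchange, so nothing can be read from the data about what it does. The two measured values cover a wide span, yet neither bears on a cyano group. On that basis the step from compound 2 to compound 3 is expected to be small, a 1.3-fold lower number from compound 2 to compound 3 (0.11 log units; within the scatter), not clearly beyond the scatter in either direction. Compound 3 is therefore estimated at 100 nM, with a range from 30 nM to 400 nM.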

Compound 3, half-maximal effective concentration: 3470 nM
Compound 3: middle estimate off by 35-fold (1.54 log units), on the low side, and the stated range ends below it.
By their numbers in this assay, from the lowest: compound 1; then compound 2; then compound 3.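

In this assay, within the data shown here, the exchange of fluoro for cyano on the aromatic carbon para to a large group is the first single-place change that can be read, and its step is large: a 27-fold higher number from compound 2 to compound 3 (1.43 log units; beyond the scatter). This shows that the number is highly sensitive to the group at this position, since 4-fluorophenyl and 4-cyanophenyl stand far apart on an otherwise identical structure. Nothing available explains why the number rises so far.

From the compounds shown here alone, whether this rise is particular to the cyano group, or would also follow a chloro, methoxy or amino group at the same place, remains open. Also open, going by these compounds, is whether the exchange would have a similar size on the pentafluorinated ring of compound 1, as this single pair is all that speaks to the change.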